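Compound 4: chloro added on the pyridin-3-yl of compound 3

A few compounds are considered here, and "the series" means these few. Any claim that something is new, unique, unknown or untested is made for them only; others in the source may bear on it.

Measured so far in a functional assay on DLD-1 cells (Homo sapiens) for antiproliferative activity, read by CellTiter-Glo, with a stated time of 72 h; a higher number here means a weaker inhibitor, a lower number a stronger inhibitor:
Compound 1 `Cc1noc(C)c1S(=O)(=O)N1CCC(N2CCC(C)CC2)CC1` sits at the assay limit, > 5000 nM.
Compound 2 `CC1CCN(C2CCN(S(=O)(=O)c3cccnc3Cl)CC2)CC1` likewise sits at the assay limit, > 5000 nM.
Compound 3 `CC1CCN(C2CCN(S(=O)(=O)c3cccnc3)CC2)CC1` gives 2400 nM.

Among the measured compounds shown here, compound 3 is thus the only member with a read number; the other two values are limits, not numbers (the limit of > 5000 nM in this assay, at which 2 of the 3 values shown sit). Compound 4 `CC1CCN(C2CCN(S(=O)(=O)c3ccc(Cl)nc3)CC2)CC1` differs from compound 3 by chloro in place of hydrogen on an aromatic carbon. For the measured compounds named here, two measured steps bear on it: the loss of a chloro, an at least 2.0-fold lower number from compound 2 to compound 3 (0.31 log units; beyond the scatter), and the ring exchange, an at least 2.0-fold lower number from compound 1 to compound 3 (0.31 log units; beyond the scatter); the step that the two limits leave unreadable from compound 1 to compound 2 cannot be sized. Both readable steps move toward compound 3, so a chloro entering compound 3 is expected to raise the number, plausibly back to the limit; the estimated step is a 2.3-fold higher number from compound 3 to compound 4 (0.36 log units; beyond the scatter). Compound 4 is therefore expected at 5500 nM, within 2000 nM to 16000 nM.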

Compound 4, half-maximal inhibitory concentration: 3700 nM
The estimate for compound 4 lay 1.5-fold (0.17 log units) above the measured number; the measured number falls inside the stated range.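

In this assay, among the compounds shown here, 6-chloropyridin-3-yl gives the first read number for a chlorinated member, and this position takes a chloro with a 1.5-fold higher number from compound 3 to compound 4 (0.19 log units; within the scatter). Against the other two members only floors exist, an at least 1.3-fold lower number from compound 2 to compound 4 (0.13 log units; that floor lies within the scatter) and an at least 1.3-fold lower number from compound 1 to compound 4 (0.13 log units; that floor lies within the scatter), so neither the place of the chloro on the pyridine nor the exchange of the oxazole is sized here: the limit of > 5000 nM in this assay, at which 2 of the 4 values shown sit.

Open, going by these compounds, is whether a methoxy, an amine or a nitrile on this same carbon would separate from compound 3. Also open, on these data alone, is whether any group here gives a clearly lower number than compound 3.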